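Swapping a Furan Amide for a Phenyl Urea

The source may report more compounds than this note shows. Statements on the series, on what has been measured and on what is new or still open speak of the compounds shown alone.

Compound 1, `CN(C(=O)C(C)(C)C)c1ccc2[nH]c(-c3n[nH]c4ccccc34)cc2n1`, gives 8390 nM in a functional assay on KB cells (Homo sapiens) for antiproliferative activity, read by MTT assay, with a stated time of 72 h; a higher number here means a weaker inhibitor, a lower number a stronger inhibitor.
Compound 2, `COc1cccc(C(=O)N(C)c2ccc3[nH]c(-c4n[nH]c5ccccc45)cc3n2)c1`, gives 9010 nM in this assay.
Compound 3, `CN(C(=O)c1ccco1)c1ccc2[nH]c(-c3n[nH]c4ccccc34)cc2n1`, gives 19400 nM in this assay.

Compound 3 has the highest number of the three, so it is the weakest inhibitor here. Its nearest neighbour is compound 2, with a 2.2-fold higher number from compound 2 to compound 3 (0.33 log units; beyond the scatter); the furthest is compound 1, with a 2.3-fold higher number from compound 1 to compound 3 (0.36 log units; beyond the scatter). The step from compound 1 to compound 2 is a 1.1-fold higher number from compound 1 to compound 2 (0.03 log units; within the scatter).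

Compound 4, `CN(C(=O)Nc1ccccc1)c1ccc2[nH]c(-c3n[nH]c4ccccc34)cc2n1`, is reached from compound 3 by one change: anilino in place of furan-2-yl on a carbonyl carbon. Among the compounds with values here, none of the measured steps replaces a carbonyl-bound ring with a nitrogen-linked ring, so no direct precedent exists. What the three measured compounds do show is that varying the group on the carbonyl carbon moves the number only modestly, and compound 3 already sits at the high end of that spread. The expectation for compound 4 is therefore a small move, most likely back toward the values of compounds 1 and 2, giving a 1.6-fold lower number from compound 3 to compound 4 (0.21 log units; within the scatter). Compound 4 is estimated at 12000 nM, within a range from 5000 nM to 40000 nM.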

Compound 4, half-maximal inhibitory concentration: 32 nM
Beside the measured number, compound 4's estimate is 380-fold (2.57 log units) above it; measured number below the stated range.
By their numbers in this assay, from the lowest: compound 4; then compounds 1 and 2 (each within the scatter of the next); then compound 3.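

In this assay, within the data shown here, the group on this carbonyl carbon matters far more than the earlier compounds suggested: the change to anilino gives large steps from each of them (a 610-fold lower number from compound 3 to compound 4 (2.78 log units; beyond the scatter); a 280-fold lower number from compound 2 to compound 4 (2.45 log units; beyond the scatter); a 260-fold lower number from compound 1 to compound 4 (2.42 log units; beyond the scatter)). Tert-butyl, 3-methoxyphenyl and furan-2-yl differ from one another by modest steps at most, while anilino, which joins its ring to the carbonyl carbon through nitrogen, stands well apart from all three. Nothing available here accounts for this jump, so the part of the anilino group responsible stays unidentified.

A benzyl group, with carbon in place of the anilino nitrogen, would test whether that nitrogen is needed. A methylamino group would test whether the phenyl ring is, and a chlorine or methoxy on that ring would show how much room remains to change it.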